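The source may report more compounds than this note shows. Statements on the series, on what has been measured and on what is new or still open speak of the compounds shown alone.

Measured in a functional assay on MCF7 cells (Homo sapiens) for cytotoxicity, read by MTT assay, with a stated time of 72 h; on this read-out lower numbers stand for stronger inhibition and higher numbers for weaker inhibition:
Compound 1 `CNC(=O)c1cc(Oc2ccc(NC(=O)c3cc(-c4ccc(C(F)(F)F)cc4)ncn3)cc2F)ccn1`: > 100000 nM
Compound 2 `CNC(=O)c1cc(Oc2ccc(NC(=O)c3cc(-c4ccc(C)cc4)ncn3)cc2F)ccn1`: 19200 nM
Compound 3 `CNC(=O)c1cc(Oc2ccc(NC(=O)c3cc(-c4ccccc4)ncn3)cc2F)ccn1`: 32400 nM

The entry for compound 1, > 100000 nM, is a limit of the assay and not a number. That leaves two true numbers, and compound 3 at 32400 nM lies within the scatter of compound 2 at 19200 nM.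

Compound 4 `CNC(=O)c1cc(Oc2ccc(NC(=O)c3cc(-c4ccc(F)cc4)ncn3)cc2F)ccn1` carries fluoro in place of hydrogen on an aromatic carbon, (fluoro in place of hydrogen on an aromatic carbon), which turns phenyl into 4-fluorophenyl. Among the measured compounds shown here, three measured steps concern that same carbon. Hydrogen in place of methyl gave a 1.7-fold higher number from compound 2 to compound 3 (0.23 log units; within the scatter), which stays within the scatter. Methyl in place of trifluoromethyl gave an at least 5.2-fold lower number from compound 1 to compound 2 (0.71 log units; beyond the scatter), and hydrogen in place of trifluoromethyl gave an at least 3.0-fold lower number from compound 1 to compound 3 (0.48 log units; beyond the scatter). Both of these lie beyond the scatter, and both are only bounds on the size.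

None of these steps involves fluoro, so they guide the expectation only loosely. The step of a 1.7-fold higher number from compound 2 to compound 3 (0.23 log units; within the scatter) suggests little movement, while the two steps from compound 1 leave room on the high side in this assay. The expected change is a 1.2-fold lower number from compound 3 to compound 4 (0.06 log units; within the scatter), an estimated step within the scatter and with no firm direction. Compound 4 is expected at about 28000 nM, with an estimated range from 12000 nM to 70000 nM.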

Compound 4, half-maximal inhibitory concentration: > 100000 nM
Compound 4: only a limit was reported (the forecaster's own chance of this, stated with the estimate: 12%); middle value at least 3.5-fold (0.55 log units) from the limit.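

Fluoro in place of hydrogen on this aromatic carbon moves the read-out in this assay beyond the scatter, with an at least 3.0-fold higher number from compound 3 to compound 4 (0.48 log units; beyond the scatter), and fluoro in place of methyl does the same, with an at least 5.2-fold higher number from compound 2 to compound 4 (0.71 log units; beyond the scatter). Before this result, only trifluoromethyl had set a compound apart at this carbon, whereas now a single fluorine atom does too, so compound 1 and compound 4, which both carry fluorine here, stand apart from compound 2 and compound 3, whose methyl and hydrogen lie within the scatter of each other. Both new steps give only a bound on their size, and the step between compound 1 and compound 4 cannot be read, for both entries are one and the same limit and not numbers: the limit of > 100000 nM in this assay, at which 2 of the 4 values shown sit.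

The compounds shown leave open how fluoro and trifluoromethyl rank against each other at this carbon, since neither has a true number. They also leave open whether chloro, methoxy, an amine or a carboxylic acid on this carbon would fall with hydrogen and methyl or with fluoro and trifluoromethyl.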